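Swapping 4-acetylphenyl for 3-bromo-4-methylphenyl in a Narrow Series

A few compounds are considered here, and "the series" means these few. Any claim that something is new, unique, unknown or untested is made for them only; others in the source may bear on it.

Of the compounds shown here, three sharing one core have been measured in a functional assay on A549 cells (Homo sapiens) for antiproliferative activity, read by MTT assay (a higher number here means a weaker inhibitor, a lower number a stronger inhibitor), so far. Compound 1 (`Cc1c(-n2cc(COc3ccc(/C=C/C(=O)c4cc5c(cc4O)OC(C)(C)CC5)cc3)nn2)cccc1[N+](=O)[O-]`) gives 65900 nM as its value, compound 2 (`COc1ccc(-n2cc(COc3ccc(/C=C/C(=O)c4cc5c(cc4O)OC(C)(C)CC5)cc3)nn2)c([N+](=O)[O-])c1`) gives 99500 nM as its value and compound 3 (`CC(=O)c1ccc(-n2cc(COc3ccc(/C=C/C(=O)c4cc5c(cc4O)OC(C)(C)CC5)cc3)nn2)cc1`) gives 66300 nM as its value. Compound 3 therefore stands within the scatter of both others, and the numbers set no order among the three.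

Compound 4 (`Cc1ccc(-n2cc(COc3ccc(/C=C/C(=O)c4cc5c(cc4O)OC(C)(C)CC5)cc3)nn2)cc1Br`) carries 3-bromo-4-methylphenyl in place of 4-acetylphenyl on an aromatic nitrogen of a five-membered aromatic ring with 3 nitrogen (3-bromo-4-methylphenyl in place of 4-acetylphenyl on an aromatic nitrogen). The measured steps that bear on this change exchange the group at that same place. They are a 1.5-fold higher number from compound 1 to compound 2 (0.18 log units; within the scatter) and a 1.0-fold higher number from compound 1 to compound 3 (0.00 log units; within the scatter) as well as a 1.5-fold lower number from compound 2 to compound 3 (0.18 log units; within the scatter) and all of them lie within the scatter. Going by the values given here, none of the measured compounds carries bromine, so these steps offer only indirect guidance. No step beyond the scatter is therefore expected in this assay for this exchange. The expected change is a 1.1-fold higher number from compound 3 to compound 4 (0.02 log units; within the scatter) and it is not expected to exceed the scatter. Compound 4 is estimated at 70000 nM with an expected range of 35000 nM to 130000 nM around that figure.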

Compound 4, half-maximal inhibitory concentration: 125000 nM
For compound 4 the middle estimate is 1.8-fold (0.25 log units) below the measured one; measured number inside the range.
By their numbers in this assay, from the lowest: compounds 1, 3, 2 and 4 (each within the scatter of the next).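

In this assay compound 4 is the only one shown that carries bromine, and exchanging 4-acetylphenyl for 3-bromo-4-methylphenyl on the aromatic nitrogen gives a 1.9-fold higher number from compound 3 to compound 4 (0.28 log units; within the scatter). Against the other two groups at this place, the steps are a 1.3-fold higher number from compound 2 to compound 4 (0.10 log units; within the scatter) and a 1.9-fold higher number from compound 1 to compound 4 (0.28 log units; within the scatter), so bromine extends the range of groups tried here without yielding a step that leaves the scatter, and no order can be set among the four compounds. Nothing measured alongside these numbers offers an explanation for them.

Every group shown at this place is a substituted phenyl, so it remains open whether an amine, a carboxylic acid or a longer alkyl chain on the aromatic nitrogen would shift the number beyond the scatter. The compounds also leave open how much of the level seen across the series is set by the shared core, which is the same in all four and so cannot be judged from them.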